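The source may hold more compounds than are shown below. What is called first, only, known or untested is meant among the compounds shown, and "the series" means these compounds.

Of the compounds shown here, three have so far been measured in a functional assay on HL-60 cells (Homo sapiens) for cytotoxicity, read by MTT assay; on this read-out higher numbers stand for weaker inhibition and lower numbers for stronger inhibition. Compound 1 `OCc1cc(OCc2cc(O)ccc2O)cc(Cl)c1O` gives 5300 nM, compound 2 `OCc1cc(OCc2cc(O)ccc2O)ccc1O` gives 54700 nM, and compound 3 `COCc1cc(O)c(Cc2cc(O)ccc2O)cc1O` gives 6300 nM. Compound 3 therefore sits within the scatter of compound 1 and well under compound 2. Among the compounds with values here, the single measured step, a 10-fold higher number from compound 1 to compound 2 (1.01 log units; beyond the scatter), concerns a change unlike the one now considered. Compound 4 `COCc1cc(O)c(Cc2cc(O)c(Cc3cc(O)ccc3O)cc2O)cc1O` carries 2,5-dihydroxybenzyl in place of hydrogen on an aromatic carbon. Within the data shown here, no measured step speaks to putting 2,5-dihydroxybenzyl in place of hydrogen, so the expectation rests on compound 3 alone. Compound 4 is expected to give about 4000 nM, within a range from 1000 nM to 16000 nM. That estimate corresponds to a step of a 1.6-fold lower number from compound 3 to compound 4 (0.20 log units; within the scatter), which is expected to remain within the scatter.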

Compound 4, half-maximal inhibitory concentration: 33300 nM
The estimate for compound 4 lay 8.3-fold (0.92 log units) below the measured number; measured number above the stated range.
By their numbers in this assay, from the lowest: compounds 1 and 3 (each within the scatter of the next); then compounds 4 and 2 (each within the scatter of the next).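

In this assay, 2,5-dihydroxybenzyl on this aromatic carbon, ortho to a hydroxy group, brings a 5.3-fold higher number from compound 3 to compound 4 (0.72 log units; beyond the scatter) and so weakens inhibition. This position therefore responds to substitution, and this large group costs activity on the core of compound 3. Nothing available explains this loss.

From the compounds shown here alone, whether a small group such as methyl or an amine on the same carbon would also weaken inhibition remains open. So does whether a plain benzyl, without the two hydroxy groups, would behave like 2,5-dihydroxybenzyl.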